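The source may report more compounds than this note shows. Statements on the series, on what has been measured and on what is new or still open speak of the compounds shown alone.

Compound 1 `COc1ccc(/C=C/C(=O)O)c(OC(=O)c2nc(C)c(C)nc2C)c1`: 18%
Compound 2 `COc1ccc(/C=C/C(=O)O)cc1OC(=O)c1nc(C)c(C)nc1C`: 216%

Of the compounds shown here, two have been measured. In a functional assay on EA.hy 926 cells (Homo sapiens) for cytotoxicity, read by MTT assay, with stated times of 24 h and 12 h, tested at 100 uM (a lower number here means a weaker effect, a higher number a stronger effect of the compound at the concentration tested), compound 1 gives 18%, and compound 2 gives 216%, the higher of the two numbers by a margin beyond the usual scatter. Compound 2 is thus the starting point, and compound 3 `CCOC(=O)/C=C/c1ccc(OC)c(OC(=O)c2nc(C)c(C)nc2C)c1` is the next step from it. The change is ethyl in place of hydrogen on an oxygen next to a carbonyl group: in words, ethyl in place of hydrogen on an oxygen next to a carbonyl group, turning the carboxy group into an ethoxycarbonyl group. Among the measured compounds shown here, no pair of measured compounds shows this kind of change, so its effect on this assay is unknown here. A step of moderate size, more likely downward than upward, is expected, with wide uncertainty. Compound 3 is estimated at 150%, between 60% and 240%, which is a step of a number 66 percentage points lower from compound 2 to compound 3 (beyond the scatter).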

Compound 3, a percentage reported as activity, at one concentration (the size of the read-out at that concentration, not a potency): 117%
Estimate against measurement, compound 3: 33 percentage points above, and the stated range covers the measured number.
By their numbers in this assay, from the lowest: compound 1; then compound 3; then compound 2.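

Turning the carboxy group into an ethoxycarbonyl group gives, in this assay, a number 99 percentage points lower from compound 2 to compound 3 (beyond the scatter). Among the compounds shown here, this is the first sign that the read-out responds strongly to a change at this oxygen, although compound 3 still gives 117%, so the number is lowered but not lost. Nothing shown here gives a reason for this drop.

As far as these compounds go, a single step cannot separate the effect of losing the hydrogen from that of adding ethyl, so it remains open how a methyl group or a longer chain such as butyl on this oxygen would compare, or an amide in place of the ester. From the compounds shown here alone, it is also open whether the same change would have a similar effect on compound 1.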